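Phenyl to pyrimidinyl swap on the biaryl arm

The source may report more compounds than this note shows. Statements on the series, on what has been measured and on what is new or still open speak of the compounds shown alone.

Measured compounds:
compound 1 `Cc1ccc(CNc2nc(-c3ccccc3C(F)(F)F)nc3ccccc23)s1` — 5100 nM
compound 2 `FC(F)(F)c1ccccc1-c1nc(NCc2ccc(-c3ccccc3)cc2)c2ccccc2n1` — 3700 nM

In an assay on a protein complex for inhibition of ubiquitin carboxyl-terminal hydrolase 1/WD repeat-containing protein 48 (Homo sapiens), read by fluorescence (on this read-out higher numbers stand for weaker inhibition and lower numbers for stronger inhibition), compound 2 gives 3700 nM and compound 1 gives 5100 nM; these two numbers sit within the usual scatter of each other, so no ranking between them is claimed, and compound 2 is simply the reference point for the next step.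

Compound 3 `FC(F)(F)c1ccccc1-c1nc(NCc2ccc(-c3cncnc3)cc2)c2ccccc2n1` differs from compound 2 in one place: pyrimidin-5-yl in place of phenyl on an aromatic carbon. Going by the values given here, no measured pair shows a comparable exchange, so there is no precedent to scale from; the shared core and the trifluoromethyl-bearing ring are unchanged.

Expectation for compound 3 in this assay: no step beyond the scatter is expected in either direction, the estimated change from a 1.1-fold higher number from compound 2 to compound 3 (0.03 log units; within the scatter) being small. The estimated value for compound 3 is 4000 nM, with a range from 1500 nM to 11000 nM.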

Compound 3, half-maximal inhibitory concentration: 3000 nM
Estimate against measurement, compound 3: 1.3-fold (0.12 log units) above; measured number inside the range.
By their numbers in this assay, from the lowest: compounds 3, 2 and 1 (each within the scatter of the next).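

In this assay, placing pyrimidin-5-yl in place of phenyl, on an aromatic carbon para to a large group, produces a 1.2-fold lower number from compound 2 to compound 3 (0.09 log units; within the scatter), so compound 2 and compound 3 cannot be told apart. This position therefore accepts a six-membered aromatic ring with 2 hetero atoms and 2 hydrogen-bond acceptors in place of a ring of carbon only, with no step beyond the scatter on this read-out. No measurement here offers an explanation for this result.

Going by these compounds, whether an amine or a carboxylic acid on this ring, or a morpholine in place of pyrimidin-5-yl, would produce a step beyond the scatter remains open. Also open, on these data alone, are how pyridin-3-yl would read at this position and whether the exchange would read the same with a nitrile in place of trifluoromethyl.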